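A Methoxy Added to the Benzoyl Ring

The compounds below may be only part of what the source reports. "The series", "measured", "known", "first", "only" and "open" are said of these compounds alone.

Measured compounds:
compound 1, `COc1cccc(OC)c1C(=O)Nc1ccc(C(=O)/C=C/c2nc(C)c(C)nc2C)cc1` — 8470 nM
compound 2, `Cc1nc(C)c(/C=C/C(=O)c2ccc(NC(=O)c3ccccc3)cc2)nc1C` — 7270 nM

In a functional assay on A549 cells (Homo sapiens) for antiproliferative activity, read by CCK-8 assay, with a stated time of 72 h (a higher number here means a weaker inhibitor, a lower number a stronger inhibitor), compound 2 gives 7270 nM. Compound 1 gives 8470 nM in this assay, and the two numbers sit within the scatter of each other, so neither can be called the stronger inhibitor. Compound 3, `COc1ccc(C(=O)Nc2ccc(C(=O)/C=C/c3nc(C)c(C)nc3C)cc2)cc1`, has not yet been measured. It differs from compound 2 by methoxy in place of hydrogen on an aromatic carbon. Among the measured compounds shown here, the only measured step that speaks to this change is a 1.2-fold lower number from compound 1 to compound 2 (0.07 log units; within the scatter), where two methoxy groups left the same benzoyl ring without a difference beyond the scatter. A single methoxy entering that ring is therefore expected to move this assay little if at all. The step of a 1.0-fold lower number from compound 2 to compound 3 (0.02 log units; within the scatter) is the expected outcome, none beyond the scatter. Compound 3 is estimated to give 7000 nM, within a range from 3500 nM to 14000 nM.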

Compound 3, half-maximal inhibitory concentration: 4150 nM
Beside the measured number, compound 3's estimate is 1.7-fold (0.23 log units) above it, within the range that was stated.
By their numbers in this assay, from the lowest: compounds 3, 2 and 1 (each within the scatter of the next, the first and the last beyond it).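

In this assay the single methoxy on the benzoyl ring, para to a large group, gives a 1.8-fold lower number from compound 2 to compound 3 (0.24 log units; within the scatter) and so still cannot be told apart from hydrogen at this position. Among the compounds shown here, the comparison with the doubly substituted ring adds something new: 4-methoxyphenyl in place of 2,6-dimethoxyphenyl gives a 2.0-fold lower number from compound 1 to compound 3 (0.31 log units; beyond the scatter) and is the first step here to pass the scatter, though only modestly. The number of methoxy groups on this ring and where they sit can therefore shift the result a little, but nothing available explains why.

From the compounds shown here alone, whether an amine, a hydroxyl or a fluorine at the same position would give a step beyond the scatter remains open. So does the effect of a longer chain, such as ethoxy or butoxy, in place of the methoxy.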